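The compounds below may be only part of what the source reports. "The series", "measured", "known", "first", "only" and "open" are said of these compounds alone.

Among the measured compounds shown here, compound 1 `COc1ccc(-c2nc3sc(Cc4ccccc4)nn3c2SC#N)cc1` is one of two compounds measured in a functional assay on NSCLC cells (Homo sapiens) for inhibition; on this read-out higher numbers stand for weaker inhibition of growth and lower numbers for stronger inhibition of growth. In this assay compound 1 gives 4600 nM, which is the highest of the two numbers seen so far. The nearest number belongs to compound 2 `O=Cc1c(-c2ccc(Br)cc2)nc2sc(Cc3ccccc3)nn12`, which in this assay gives 4200 nM; the two values lie within the scatter of each other, so nothing separates compound 1 from compound 2 on this read-out. For the measured compounds named here, no step between measured compounds that differ in one place has been recorded, so the two values simply stand side by side.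

Compound 3 `N#CSc1c(-c2ccccc2)nc2sc(Cc3ccccc3)nn12` has not yet been measured in this assay. It differs from compound 1 in one place: hydrogen in place of methoxy on an aromatic carbon. The change leaves the shared core untouched and removes only the methoxy, so that a hydrogen sits on the aromatic carbon para to a large group.

Going by the values given here, with no measured step of this kind to rest on, the expected step from compound 1 to compound 3 is small, a 1.1-fold higher number from compound 1 to compound 3 (0.04 log units; within the scatter), and likely not beyond the scatter. Compound 3 is therefore expected to give about 5000 nM in this assay, within a range from 2000 nM to 12000 nM.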

Compound 3, concentration for 50% growth inhibition: 6000 nM
Compound 3: middle estimate off by 1.2-fold (0.08 log units), on the low side, and the stated range covers the measured number.
By their numbers in this assay, from the lowest: compounds 2, 1 and 3 (each within the scatter of the next).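

Among the compounds shown here, replacing methoxy with hydrogen on the aromatic carbon para to a large group gives, in this assay, a 1.3-fold higher number from compound 1 to compound 3 (0.12 log units; within the scatter), and this is the first step between compounds that differ in one place. Compound 1 and compound 3 therefore cannot be told apart on this read-out, so the 4-methoxyphenyl to phenyl change shows that the methoxy is not required for the growth inhibition seen with compound 1, at least for this shared core and in these cells. No evidence at hand explains this result, or shows what the methoxy might contribute beyond this single read-out.

The compounds shown leave open whether any other group on this aromatic carbon, such as an amine, a carboxylic acid, a fluorine atom or a longer alkoxy chain, would move the number beyond the scatter in either direction. They also leave open whether the same carbon would respond any differently if the change were made while the remainder of the molecule carried a different group in place of the benzyl.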